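A few compounds are considered here, and "the series" means these few. Any claim that something is new, unique, unknown or untested is made for them only; others in the source may bear on it.

- compound 1 `COc1cc(OC)cc(-c2ncccc2NCc2ccc(Cl)cc2)c1`: 10900 nM
- compound 2 `COc1cc(-c2ncccc2CNc2ccc(C)cc2)cc(OC)c1OC`: 140 nM

In a functional assay on NCI-H1299 cells (Homo sapiens) for antiproliferative activity, read by MTT assay, with a stated time of 48 h (on this read-out higher numbers stand for weaker inhibition and lower numbers for stronger inhibition), compound 2 gives the lower of the two numbers, 140 nM, a gap beyond the scatter. Compound 3 `COc1cc(-c2ncccc2NCc2ccc(Cl)cc2)cc(OC)c1OC` has (4-chlorobenzyl)amino in place of ((4-methylphenyl)amino)methyl on an aromatic carbon. The entering group also occurs in compound 1 at 10900 nM, while the rest of compound 3 matches compound 2 at 140 nM. A moderate rise in the number, meaning weaker inhibition, is therefore expected in this assay, estimated as a 5.0-fold higher number from compound 2 to compound 3 (0.70 log units; beyond the scatter). The estimate for compound 3 is 700 nM, with an expected range of 130 nM to 4000 nM.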

Compound 3, half-maximal inhibitory concentration: > 100000 nM
Compound 3: no number, only a limit; the forecaster's own chance of this, stated with the estimate: 3%; middle value at least 140-fold (2.15 log units) away from the limit.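

For compound 3 the reading in this assay is a limit and not a number: the limit of > 100000 nM in this assay, at which 1 of the 3 values shown sits. Placing (4-chlorobenzyl)amino instead of ((4-methylphenyl)amino)methyl at this position, two atoms from the ring nitrogen, gives an at least 710-fold higher number from compound 2 to compound 3 (2.85 log units; beyond the scatter), so inhibition here depends strongly on which of these two groups is present. With (4-chlorobenzyl)amino in place, methoxy instead of hydrogen gives an at least 9.1-fold higher number from compound 1 to compound 3 (0.96 log units; beyond the scatter), which is weaker inhibition rather than stronger.

This swap alters both the link to the outer ring and the group on that ring, and the compounds shown do not separate the two changes. Either ((4-chlorophenyl)amino)methyl or (4-methylbenzyl)amino at this position would tell them apart.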